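The source may report more compounds than this note shows. Statements on the series, on what has been measured and on what is new or still open speak of the compounds shown alone.

Of the compounds shown here, three sharing one core have been measured so far in an ADME assay on MT4 cells (Homo sapiens) for cytotoxicity, read by MTT assay; a higher number here means that more compound is tolerated, a lower number that less compound is tolerated. Compound 1 `Cc1cc(C)cc(S(=O)(=O)c2c(C(=O)NCc3cccc(O)c3)[nH]c3ccc(Cl)cc23)c1` gives 27000 nM and compound 2 `Cc1cc(C)cc(S(=O)(=O)c2c(C(=O)NC(C)c3cccc(O)c3)[nH]c3ccc(Cl)cc23)c1` gives 16000 nM, while compound 3 `Cc1cc(C)cc(S(=O)(=O)c2c(C(=O)NCc3ccc(O)cc3)[nH]c3ccc(Cl)cc23)c1` gives 6250 nM as the lowest of the three numbers.

Compound 4 `COc1cc(CNC(=O)c2[nH]c3ccc(Cl)cc3c2S(=O)(=O)c2cc(C)cc(C)c2)ccc1O` differs from compound 3 by one change on the ring that carries the hydroxy group, namely methoxy in place of hydrogen on an aromatic carbon on the way from 4-hydroxybenzyl to 4-hydroxy-3-methoxybenzyl. Among the measured compounds shown here, no measured step adds a group to this ring, so the evidence is only indirect. The nearest guide is a 4.3-fold lower number from compound 1 to compound 3 (0.64 log units; beyond the scatter), a modest step in which only the place of the hydroxy group on the ring changes. A second modest step is a 2.6-fold lower number from compound 2 to compound 3 (0.41 log units; beyond the scatter), although it alters the chain as well as the ring. Adding a methyl to the chain gives a 1.7-fold lower number from compound 1 to compound 2 (0.23 log units; within the scatter) and stays within the scatter.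

With compound 3 at 6250 nM at the bottom of the range so far, a slight rise in this assay seems likelier than a fall, though the direction is uncertain. The step expected is a 1.6-fold higher number from compound 3 to compound 4 (0.20 log units; within the scatter) and it may not clear the scatter. For compound 4 the estimated value is 10000 nM with 3500 nM to 30000 nM as the expected range.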

Compound 4, half-maximal cytotoxic concentration: 28700 nM
The estimate for compound 4 lay 2.9-fold (0.46 log units) below the measured number, and the stated range covers the measured number.
By their numbers in this assay, from the lowest: compound 3; then compounds 2, 1 and 4 (each within the scatter of the next).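

In this assay, among the compounds shown here, methoxy in place of hydrogen on an aromatic carbon, ortho to a hydroxy group, gives a 4.6-fold higher number from compound 3 to compound 4 (0.66 log units; beyond the scatter) and is the first measured step that adds a group to this ring, showing that such an addition can move the number beyond the scatter, towards more compound being tolerated. The other two comparisons give a 1.1-fold higher number from compound 1 to compound 4 (0.03 log units; within the scatter) and a 1.8-fold higher number from compound 2 to compound 4 (0.25 log units; within the scatter) and both remain within the scatter, so compound 4 falls in with compound 1 and compound 2, leaving compound 3 alone as the lowest of the four. Nothing available here explains why the methoxy group has this effect.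

Going by these compounds, this is one group at one ring position, so it remains open whether fluorine, ethoxy or an amine at the same place would give a similar step. On these data alone, it is also open whether methoxy would behave the same way without the neighbouring hydroxy group, or on the ring of compound 1, where the hydroxy group sits elsewhere.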